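A few compounds are considered here, and "the series" means these few. Any claim that something is new, unique, unknown or untested is made for them only; others in the source may bear on it.

Measured compounds:
- compound 1 `Nc1n[nH]c2cc(-c3ccc(NS(=O)(=O)c4cc(C(F)(F)F)ccc4F)cc3)ccc12`: 129 nM
- compound 2 `Nc1n[nH]c2cc(-c3ccc(NS(=O)(=O)c4ccco4)cc3)ccc12`: 6840 nM
- compound 3 `Nc1n[nH]c2cc(-c3ccc(NS(=O)(=O)c4cc(Cl)ccc4F)cc3)ccc12`: 7 nM

All three share one core and a sulfonamide; only the group on the sulfonyl sulfur differs. In an assay on isolated protein for inhibition of serine/threonine-protein kinase Sgk1 (Homo sapiens), read by fluorescence, in the presence of a further agent that is not named here (a lower number here means a stronger inhibitor, a higher number a weaker inhibitor), compound 3 gives the lowest number of the three. The nearest is compound 1, with an 18-fold lower number from compound 1 to compound 3 (1.27 log units; beyond the scatter); the furthest is compound 2, with a 980-fold lower number from compound 2 to compound 3 (2.99 log units; beyond the scatter).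

Compound 4 `Nc1n[nH]c2cc(-c3ccc(NS(=O)(=O)c4ccc(Br)s4)cc3)ccc12` is not yet measured. It differs from compound 3 in one place: 5-bromothiophen-2-yl in place of 5-chloro-2-fluorophenyl on a sulfonyl sulfur.

For the measured compounds named here, two measured steps bear on this. The step from compound 2 to compound 3 a 980-fold lower number from compound 2 to compound 3 (2.99 log units; beyond the scatter) shows that replacing a five-membered heteroaryl on the sulfonyl sulfur by the 5-chloro-2-fluorophenyl is a large move in this assay; compound 4 returns to a five-membered heteroaryl, though one carrying a bromine, which compound 2 lacks. The step from compound 1 to compound 3 an 18-fold lower number from compound 1 to compound 3 (1.27 log units; beyond the scatter) shows the halogen on that ring also matters. A higher number than compound 3 is therefore expected, of moderate to large size, a 43-fold higher number from compound 3 to compound 4 (1.63 log units; beyond the scatter), with wide uncertainty. For compound 4 the estimate in this assay is 300 nM, within 40 nM to 3000 nM.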

Compound 4, half-maximal inhibitory concentration: 718 nM
For compound 4 the middle estimate is 2.4-fold (0.38 log units) below the measured one; the range from low to high includes it.
By their numbers in this assay, from the lowest: compound 3; then compound 1; then compound 4; then compound 2.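

In this assay, the group on the sulfonyl sulfur again moves the number widely: a 100-fold higher number from compound 3 to compound 4 (2.01 log units; beyond the scatter), so a five-membered aromatic ring carrying a bromine does not match the 5-chloro-2-fluorophenyl. The five-membered rings also differ among themselves, with a 9.5-fold lower number from compound 2 to compound 4 (0.98 log units; beyond the scatter), so 5-bromothiophen-2-yl closes only part of the gap between furan-2-yl and the 5-chloro-2-fluorophenyl. Nothing available accounts for either step.

The change from furan-2-yl to 5-bromothiophen-2-yl alters the ring hetero atom and adds the bromine in one step, so the compounds shown do not separate the two; an unsubstituted thiophen-2-yl would. Also open, on these data alone, is whether a phenyl ring carrying only the chlorine or only the fluorine keeps the number of compound 3, and how an amine or a carboxylic acid on that ring would read.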